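Changing the benzyl group of compound 3

A few compounds are considered here, and "the series" means these few. Any claim that something is new, unique, unknown or untested is made for them only; others in the source may bear on it.

Measured compounds:
compound 1, `CC(C)Cc1ccc2c(NCCCNCc3ccco3)ccnc2c1`: 16000 nM
compound 2, `COc1ccc(F)cc1CNCCCNc1ccnc2cc(CC(C)C)ccc12`: 2900 nM
compound 3, `COc1cccc(CNCCCNc2ccnc3cc(-c4cc(C(F)(F)F)cc(C(F)(F)F)c4)ccc23)c1O`: 940 nM

In an ADME assay on HepG2 cells (Homo sapiens) for cytotoxicity, read by luminescence, CellTiter-Glo and ATP content, with a stated time of 72 h (on this read-out higher numbers stand for an effect only at larger amounts of compound and lower numbers for an effect already at smaller amounts), compound 3 gives the lowest of the three numbers; compound 2 stands next above it, and compound 1 lies furthest away. Compound 4, `COc1ccc(F)cc1CNCCCNc1ccnc2cc(-c3cc(C(F)(F)F)cc(C(F)(F)F)c3)ccc12`, differs from compound 3 in one place: 5-fluoro-2-methoxyphenyl in place of 2-hydroxy-3-methoxyphenyl on a saturated chain carbon bound to an amine nitrogen. Among the compounds with values here, only one measured step touches this change, a 5.5-fold lower number from compound 1 to compound 2 (0.74 log units; beyond the scatter), and there the entering group replaced a furan-2-yl rather than a 2-hydroxy-3-methoxyphenyl, so it is an indirect guide at best. Within the data shown here, no measured pair shows the direct exchange. Compound 4 joins the benzyl group of compound 2 to the remainder of compound 3, which already holds the lowest number. A small step, a 1.2-fold lower number from compound 3 to compound 4 (0.07 log units; within the scatter), is expected, near the scatter. Compound 4 is therefore estimated at 800 nM, with a range from 300 nM to 2000 nM.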

Compound 4, half-maximal effective concentration: 870 nM
Compound 4: the middle estimate sits 1.1-fold (0.04 log units) below what was measured, and the stated range covers the measured number.
By their numbers in this assay, from the lowest: compounds 4 and 3 (each within the scatter of the next); then compound 2; then compound 1.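

In this assay, the exchange at this position, on a saturated chain carbon bound to an amine nitrogen, gives a 1.1-fold lower number from compound 3 to compound 4 (0.03 log units; within the scatter). Within the data shown here, on this core, therefore, a group with 1 hydrogen-bond donor and a group with 0 hydrogen-bond donors cannot be told apart, which the earlier compounds could not show. Nothing available explains why the two groups read alike. Open, on these data alone, is whether this tolerance extends to a benzyl group bearing a carboxylic acid or an amine. Also open, as far as these compounds go, is whether a longer chain between the two nitrogens would shift the number.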